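From 3-fluorobenzyl to ethyl: working notes on the series

The source may hold more compounds than are shown below. What is called first, only, known or untested is meant among the compounds shown, and "the series" means these compounds.

Measured in a functional assay on RAW264.7 cells (Mus musculus) for inhibition, read by Griess assay, with stated times of 1 h and 24 h; on this read-out higher numbers stand for weaker inhibition and lower numbers for stronger inhibition:
- Compound 1 `CCCOc1ccccc1C1CC(=O)c2ccccc2O1`: 46000 nM
- Compound 2 `CC(C)c1ccc(COc2ccccc2C2CC(=O)c3ccccc3O2)cc1`: 27100 nM
- Compound 3 `O=C1CC(c2ccccc2OCc2cccc(F)c2)Oc2ccccc21`: 15600 nM

The low end of these numbers is set by two steps: a 1.7-fold lower number from compound 2 to compound 3 (0.24 log units; within the scatter), and a 2.9-fold lower number from compound 1 to compound 3 (0.47 log units; beyond the scatter). Compound 3 therefore stands clear of compound 1 only.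

Compound 4 `CCOc1ccccc1C1CC(=O)c2ccccc2O1`, not yet measured, keeps the core of compound 3 and puts methyl in place of 3-fluorophenyl on a saturated chain carbon bound to an oxygen on an aromatic ring.

The closest guide is the second step above, which exchanges ethyl and 3-fluorophenyl at this same place. A weaker hint comes from the other ring-bearing compound: a 1.7-fold lower number from compound 1 to compound 2 (0.23 log units; within the scatter). Going by the values given here, no measured compound carries methyl here, so the size of the step rests on these comparisons alone.

Losing the ring is expected to give a modest rise in this assay, back towards compound 1 at 46000 nM. The expected step is a 2.9-fold higher number from compound 3 to compound 4 (0.46 log units; beyond the scatter). For compound 4 the estimated value is 45000 nM, with an expected range of 22000 nM to 90000 nM.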

Compound 4, half-maximal inhibitory concentration: 38500 nM
Beside the measured number, compound 4's estimate is 1.2-fold (0.07 log units) above it; low and high end bracket the measured number.
By their numbers in this assay, from the lowest: compounds 3, 2, 4 and 1 (each within the scatter of the next, the first and the last beyond it).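

In this assay, methyl in place of 3-fluorophenyl on a saturated chain carbon bound to an oxygen on an aromatic ring gives a 2.5-fold higher number from compound 3 to compound 4 (0.39 log units; beyond the scatter) and so stands beyond the scatter, which makes this the second short chain, after the ethyl of compound 1, to stand clear of compound 3. The two short chains themselves are not separated, with a 1.2-fold lower number from compound 1 to compound 4 (0.08 log units; within the scatter) as the step for hydrogen in place of methyl further along the chain, so chain length between these two compounds cannot be read in this assay. Carrying a ring at this place is also not enough by itself to stand clear of a short chain, as a 1.4-fold higher number from compound 2 to compound 4 (0.15 log units; within the scatter) leaves compound 2 with its 4-isopropylphenyl within the scatter of methyl, and among the four compounds only compound 3 stands clear of both short chains. No measurement on these compounds offers an explanation for these steps.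

From the compounds shown here alone, it remains open whether the separation belongs to the 3-fluorophenyl specifically or would hold for other aromatic rings at this place, such as a plain phenyl or a pyridine. Going by these compounds, the result of a longer chain, an amine or a carboxylic acid at this place also remains open.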